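The source may hold more compounds than are shown below. What is called first, only, known or untested is meant among the compounds shown, and "the series" means these compounds.

Measured so far:
- Compound 1, `Fc1ccc2c(c1CNc1ncc(Oc3ccccc3)c3nncn13)CCO2`: in a physicochemical assay for solubility, read by LC-MS, in phosphate buffer, with a stated time of 24 h, at pH 7.4 (a higher number here means a more soluble compound, a lower number a less soluble compound), compound 1 gives 8000 nM.
- Compound 2, `Cc1nc(CN(C)C)ccc1-c1cnc(NCc2c(F)ccc3c2CCO3)c2cn[nH]c(=O)c12`: in this assay compound 2 returns > 1000000 nM, which is a limit of the assay and not a number.

For the measured compounds named here, compound 1 holds the only plain number in this assay; the other reading in the set is the limit of > 1000000 nM in this assay, at which 1 of the 2 values shown sits, so the pair shows only that compound 1 sits inside the measurable range while compound 2 does not. Going by the values given here, no pair of measured compounds differs in a single place, so no measured step exists to calibrate the next change.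

Compound 3, `CN(c1ccn(C)n1)c1cnc(NCc2c(F)ccc3c2CCO3)n2cnnc12`, is the next compound for this assay. It differs from compound 1 by methyl(1-methyl-1H-pyrazol-3-yl)amino in place of phenoxy on an aromatic carbon. Among the compounds with values here, with no measured step to lean on, the direction rests on the change itself: compound 3 is expected to move upward in this assay by a margin beyond the usual scatter, a 7.5-fold higher number from compound 1 to compound 3 (0.88 log units; beyond the scatter). Compound 3 is therefore estimated at 60000 nM, within a range from 12000 nM to 300000 nM.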

Compound 3, solubility: 130000 nM
Compound 3: the middle estimate sits 2.2-fold (0.34 log units) below what was measured; the range from low to high includes it.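

For the compounds shown here, the first single-place step shows that this aromatic carbon, para to a large group, is not silent in this assay: methyl(1-methyl-1H-pyrazol-3-yl)amino in place of phenoxy gives a 16-fold higher number from compound 1 to compound 3 (1.21 log units; beyond the scatter). Neither group carries a net charge, the entering group counts 3 hydrogen-bond acceptors against 1 for phenoxy, and compound 3, at 130000 nM, still gives a plain number. Going by these compounds alone, compound 2 alone holds a limit and not a number, and no step to it can be read: the limit of > 1000000 nM in this assay, at which 1 of the 3 values shown sits.

Whether the step follows the five-membered aromatic ring or the methyl-bearing nitrogen that joins it to the core stays open, as these two parts never vary apart in the compounds shown. A morpholine or a carboxylic acid on this same aromatic carbon would show how far the number in this assay moves with a group that has no aromatic ring at all.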